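Distal aryl variation across compounds 1 to 3

The compounds below may be only part of what the source reports. "The series", "measured", "known", "first", "only" and "open" are said of these compounds alone.

Measured so far:
compound 1 `OC[C@@H]1[C@@H](O)[C@H](O)[C@@H](O)CN1CCCCCOCc1ccc(-c2ccc(C(F)(F)F)cc2)cc1`: 10 nM
compound 2 `OC[C@@H]1[C@@H](O)[C@H](O)[C@@H](O)CN1CCCCCOCc1ccc(-c2ccc3c(c2)OCCO3)cc1`: 30 nM

In an assay on isolated protein for inhibition of Beta-glucosidase (Homo sapiens) (on this read-out higher numbers stand for weaker inhibition and lower numbers for stronger inhibition), compound 1 gives 10 nM while compound 2 gives 30 nM. Compound 2 thus holds the higher of the two numbers, set apart by the step of a 3.0-fold higher number from compound 1 to compound 2 (0.48 log units; beyond the scatter). Compound 3 `OC[C@@H]1[C@@H](O)[C@H](O)[C@@H](O)CN1CCCCCOCc1ccc(-c2ccc(F)nc2)cc1` carries the change (6-fluoropyridin-3-yl in place of 2,3-dihydro-1,4-benzodioxin-6-yl on an aromatic carbon). Only one measured step bears on this: exchanging the 4-(trifluoromethyl)phenyl of compound 1 for the 2,3-dihydro-1,4-benzodioxin-6-yl of compound 2 raised the number modestly, as shown by a 3.0-fold higher number from compound 1 to compound 2 (0.48 log units; beyond the scatter). Removing that bicyclic group again is expected to reverse part of that, a step of a 2.0-fold lower number from compound 2 to compound 3 (0.30 log units; within the scatter). Compound 3 is therefore estimated at 15 nM, with a range of 5 nM to 50 nM.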

Compound 3, half-maximal inhibitory concentration: 5 nM
The estimate for compound 3 lay 3.0-fold (0.48 log units) above the measured number, and the stated range covers the measured number.
By their numbers in this assay, from the lowest: compounds 3 and 1 (each within the scatter of the next); then compound 2.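

In this assay, 6-fluoropyridin-3-yl in place of 2,3-dihydro-1,4-benzodioxin-6-yl gives a 6.0-fold lower number from compound 2 to compound 3 (0.78 log units; beyond the scatter), so the loss seen with the bicyclic group is not a general feature of changing this aryl group. In place of 4-(trifluoromethyl)phenyl, the same group gives a 2.0-fold lower number from compound 1 to compound 3 (0.30 log units; within the scatter), so a six-membered aromatic ring with a hetero atom and a carbon-only one both fit this position, para to a large group. No measurement shown accounts for either step.

As far as these compounds go, whether the ring nitrogen or the fluorine matters remains open, and 4-fluorophenyl would separate them. From the compounds shown here alone, how an amine or a carboxylic acid on this ring would read also remains open.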